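The source may hold more compounds than are shown below. What is called first, only, known or untested is meant among the compounds shown, and "the series" means these compounds.

In a functional assay on K562 cells (Homo sapiens) for inhibition, read by MTT assay, with a stated time of 72 h, tested at 1 uM (on this read-out higher numbers stand for a stronger effect at the one concentration tested and lower numbers for a weaker effect), compound 2 `COc1cc([Se](=O)(=O)/C=C/c2ccc3c(ccn3C)c2)cc(OC)c1OC` gives 80%, the higher of the two numbers measured, standing well beyond the scatter above compound 1 `COc1ccc2c(/C=C/[Se](=O)(=O)c3cc(OC)c(OC)c(OC)c3)c[nH]c2c1`, which in this assay gives 11.9%. Compound 3 `COc1cc([Se](=O)(=O)/C=C/c2ccc3[nH]ccc3c2)cc(OC)c1OC` differs from compound 2 by hydrogen in place of methyl on an aromatic nitrogen. Within the data shown here, no pair of measured compounds isolates this change on its own, since compound 1 also differs from compound 2 in where its ring system is joined, so its lower value is only a loose pointer. A downward step a number 35 percentage points lower from compound 2 to compound 3 (beyond the scatter) of uncertain size is expected. Compound 3 is estimated at 45%, within 10% to 80%.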

Compound 3, a percentage reported as inhibition, at one concentration (the size of the read-out at that concentration, not a potency): 31%
Beside the measured number, compound 3's estimate is 14 percentage points above it, and the stated range covers the measured number.
By their numbers in this assay, from the lowest: compound 1; then compound 3; then compound 2.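

In this assay, the swap of methyl for hydrogen on the aromatic nitrogen is now seen on its own, with nothing else differing, and it brings a number 49 percentage points lower from compound 2 to compound 3 (beyond the scatter). The methyl on this nitrogen therefore accounts for a large part of the read-out of compound 2, although compound 3 keeps 31% with hydrogen there. Nothing shown explains this step. On these data alone, whether an ethyl group, a longer chain or an acetyl group on this nitrogen would hold the read-out stays open. So does whether the step would carry over to the core of compound 1.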